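Moving the methoxy group on the amide-bound aryl ring

The source may report more compounds than this note shows. Statements on the series, on what has been measured and on what is new or still open speak of the compounds shown alone.

For the measured compounds named here, compound 1 `COc1ccc(N2C(=O)COc3ccc(-c4cnc(OC)c(NS(=O)(=O)c5ccc(F)cc5)c4)cc32)cc1` is the only compound of the set with a number in a functional assay on HepG2 cells (Homo sapiens) for antiproliferative activity, read by MTT assay, with a stated time of 72 h (a higher number here means a weaker inhibitor, a lower number a stronger inhibitor), where compound 1 gives 13100 nM. Compound 2 `COc1ccc(N2C(=O)COc3ccc(-c4cnc(Cl)c(NS(=O)(=O)c5ccc(F)cc5)c4)cc32)cc1` returned only a limit of the assay in this assay, > 40000 nM. That gave an at least 3.0-fold higher number from compound 1 to compound 2 (0.48 log units; beyond the scatter), a step that rests on (the limit of > 40000 nM in this assay, at which 1 of the 2 values shown sits). Compound 3 `COc1cccc(N2C(=O)COc3ccc(-c4cnc(OC)c(NS(=O)(=O)c5ccc(F)cc5)c4)cc32)c1` differs from compound 1 elsewhere: 3-methoxyphenyl in place of 4-methoxyphenyl on an amide-type nitrogen in a ring. Going by the values given here, the one measured step changes a different part of the shared core, so the pair of compound 1 and compound 2 offers no guide for the size of this change, and nothing in the data points to a shift in either direction beyond the scatter. Compound 3 is therefore expected to give an estimated 15000 nM in this assay, with a likely range of 5000 nM to 40000 nM. That estimate corresponds to an expected 1.1-fold higher number from compound 1 to compound 3 (0.06 log units; within the scatter).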

Compound 3, half-maximal inhibitory concentration: > 40000 nM
Compound 3 was reported as a limit; the forecaster's own chance of this, stated with the estimate: 25%; middle value at least 2.6-fold (0.42 log units) from the limit.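

Moving the methoxy group on the aryl ring at the amide-type nitrogen, with 3-methoxyphenyl in place of 4-methoxyphenyl, gives an at least 3.0-fold higher number from compound 1 to compound 3 (0.48 log units; beyond the scatter) in this assay. Compound 3 holds the same atoms as compound 1, joined differently, so the result shows that the place of the methoxy group on this ring matters here, which the earlier step at another part of the shared core could not show. Compound 3 gives > 40000 nM, which is a limit of the assay.

The true size of this step cannot be read because compound 3 sits at that limit: the limit of > 40000 nM in this assay, at which 2 of the 3 values shown sit. As far as these compounds go, it also remains open whether an unsubstituted phenyl or a 4-ethoxyphenyl group on the same nitrogen would stay near compound 1 or fall to the same limit.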